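This account rests on a few compounds, and the source may have more. Where it says the series, first, only, none or still open, it means among the compounds named here.

Measured in an ADME assay on microsomes from liver (Mus musculus) for metabolic stability, read by LC-MS, using NADPH, with a stated time of 10 min, tested at 10 uM; a lower number here means that the compound disappears faster, a higher number that the compound lasts longer:
- compound 1 `Nc1ncnc2c1c(Oc1cc(C(F)(F)F)ccn1)nn2[C@@H]1CCCC[C@H]1O` gives 1.1 h
- compound 2 `Nc1ncnc2c1c(Oc1cc(C(F)(F)F)ccn1)nn2C1CC1` gives > 2.41 h
- compound 3 `Nc1ncnc2c1c(Oc1cc(C(F)(F)F)ccn1)nn2[C@H]1CC[C@@H](N)CC1` gives 0.917 h

The entry for compound 2 is a limit of the assay, not a number. Compound 3 stands level with compound 1, with a 1.2-fold lower number from compound 1 to compound 3 (0.08 log units; within the scatter). Against the limit, the picture is an at least 2.6-fold lower number from compound 2 to compound 3 (0.41 log units; beyond the scatter), and an at least 2.1-fold higher number from compound 1 to compound 2 (0.34 log units; beyond the scatter).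

Compound 4 `Nc1ncnc2c1c(Oc1cc(C(F)(F)F)ccn1)nn2[C@H]1CC[C@H](CO)CC1` carries 4-(hydroxymethyl)cyclohexyl in place of 4-aminocyclohexyl on an aromatic nitrogen. The six-membered carbon ring stays, so the steps involving cyclopropyl bear on it less directly. Going by the values given here, the closest precedent is the single exchange of one substituted cyclohexyl for another, a 1.2-fold lower number from compound 1 to compound 3 (0.08 log units; within the scatter), and that step stayed within the scatter. No step beyond the scatter is therefore expected in this assay, and the estimate is a 1.1-fold higher number from compound 3 to compound 4 (0.04 log units; within the scatter). Compound 4 is expected at 1 h, with an estimated range of 0.5 h to 2 h.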

Compound 4, half-life: 0.383 h
Compound 4: the middle estimate sits 2.6-fold (0.42 log units) above what was measured, and the stated range ends above it.
By their numbers in this assay, from the lowest: compound 4; then compounds 3 and 1 (each within the scatter of the next). At a limit, above all of these: compound 2.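

In this assay, the substituent on the cyclohexyl ring now matters: a 2.4-fold lower number from compound 3 to compound 4 (0.38 log units; beyond the scatter), and a 2.9-fold lower number from compound 1 to compound 4 (0.46 log units; beyond the scatter). The earlier exchange between substituted cyclohexyl groups, a 1.2-fold lower number from compound 1 to compound 3 (0.08 log units; within the scatter), gave no sign of this, so on this aromatic nitrogen the six-membered ring alone does not fix the half-life. Against cyclopropyl the gap is an at least 6.2-fold lower number from compound 2 to compound 4 (0.79 log units; beyond the scatter), which is only a bound, as compound 2 stands at a limit of the assay: the limit of > 2.41 h in this assay, at which 1 of the 4 values shown sits.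

Still open, going by these compounds, is whether the lower number follows the hydroxymethyl group itself, which a carboxylic acid, a methoxymethyl group or a longer hydroxyethyl chain in its place could test. The compounds shown also do not tell which part of compound 4 is lost in the microsomes.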